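Tetrazole ketone series: octyl to 4-fluorophenoxy swap

A few compounds are considered here, and "the series" means these few. Any claim that something is new, unique, unknown or untested is made for them only; others in the source may bear on it.

Measured so far in an ADME assay on S9 fraction from liver (Rattus norvegicus) for metabolic stability, read by LC-MS, using NADPH, with a stated time of 30 min; on this read-out higher numbers stand for a more stable compound and lower numbers for a less stable compound:
compound 1, `CCCCCCCCc1ccc(OCC(=O)Cn2nnc(-c3ccccc3)n2)cc1`, gives 33%
compound 2, `CCCCCCCCc1ccc(OC(C)C(=O)Cn2nnc(-c3ccccc3)n2)cc1`, gives 40%
compound 3, `CC(Oc1ccc(Oc2ccc(F)cc2)cc1)C(=O)Cn1nnc(-c2ccccc2)n1`, not yet measured

Within the data shown here, only two compounds have numbers. In this assay, among the measured compounds shown here, compound 2 and compound 1 lie within the scatter of each other, so neither can be called more stable; the one known step, a number 7 percentage points higher from compound 1 to compound 2 (within the scatter), concerns the chain between the carbonyl and the aryl ether oxygen and nothing else.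

Compound 3 differs from compound 2 by 4-fluorophenoxy in place of octyl on an aromatic carbon. For the measured compounds named here, no measured step touches this position or this kind of exchange, so the step from compound 1 to compound 2 gives no guidance on direction or size; the expectation rests on compound 2 alone. Compound 3 is therefore expected to stay near compound 2, with a wide range: 45%, between 20% and 70%. This estimate corresponds to a step of a number 5 percentage points higher from compound 2 to compound 3 (within the scatter) in this assay, not resolved beyond the scatter.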

Compound 3, percent of the compound remaining: < 5%
Compound 3 was reported as a limit (the forecaster's own chance of this, stated with the estimate: 2%); at least 40 percentage points between middle value and limit.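

In this assay, 4-fluorophenoxy in place of octyl on the aromatic carbon gives a number at least 35 percentage points lower from compound 2 to compound 3 (beyond the scatter), the only step shown in the series that lies beyond the scatter. The earlier step on the chain carbon did not show this: that step stayed within the scatter, and this aromatic carbon had not been touched. Compound 3 gives < 5%, which is a limit of the assay and not a number, so the step has a bound but no exact size: the limit of < 5% in this assay, at which 1 of the 3 values shown sits.

Only one exchange at this aromatic carbon is shown, and it does not separate the ether oxygen, the ring and the fluorine of 4-fluorophenoxy as the source of the step. Also open, as far as these compounds go, is how a plain phenyl, a phenoxy without fluorine or a shorter chain such as hexyl would read at this carbon.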